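Replacing the thiophenylmethylamino arm with a methylpiperidine

The source may hold more compounds than are shown below. What is called first, only, known or untested is meant among the compounds shown, and "the series" means these compounds.

Measured so far:
compound 1 `COc1ccc(-c2cnc3nc(N)nc(NCc4ccccc4)c3n2)cc1OC` — 13000 nM
compound 2 `COc1ccc(-c2cnc3nc(N)nc(OC(C)C)c3n2)cc1OC` — 400 nM
compound 3 `COc1ccc(-c2cnc3nc(N)nc(NCc4cccs4)c3n2)cc1OC` — 4100 nM

In a functional assay on cells (T-cell, Homo sapiens) for inhibition (on this read-out higher numbers stand for weaker inhibition and lower numbers for stronger inhibition), compound 3 stands second highest of the three numbers; its nearest neighbour is compound 1, with a 3.2-fold lower number from compound 1 to compound 3 (0.50 log units; beyond the scatter) separating them, and the furthest is compound 2, with a 10-fold higher number from compound 2 to compound 3 (1.01 log units; beyond the scatter).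

Compound 4 `COc1ccc(-c2cnc3nc(N)nc(N4CCC(C)CC4)c3n2)cc1OC` differs from compound 3 in one place: 4-methylpiperidin-1-yl in place of ((thiophen-2-yl)methyl)amino on an aromatic carbon.

Among the compounds with values here, two measured steps bear on this change. Exchanging benzylamino for isopropoxy gave a 33-fold lower number from compound 1 to compound 2 (1.51 log units; beyond the scatter), and going from isopropoxy to ((thiophen-2-yl)methyl)amino gave a 10-fold higher number from compound 2 to compound 3 (1.01 log units; beyond the scatter). Both steps point the same way: when the group on this aromatic carbon is not an arylmethylamino group, the number in this assay is lower. The 4-methylpiperidin-1-yl group has not been measured here, so the size of the effect is uncertain, but a lower number is expected for compound 4, about a 4.1-fold lower number from compound 3 to compound 4 (0.61 log units; beyond the scatter). The estimate for compound 4 is 1000 nM, with a range from 250 nM to 5000 nM.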

Compound 4, half-maximal inhibitory concentration: 800 nM
For compound 4 the middle estimate is 1.3-fold (0.10 log units) above the measured one, within the range that was stated.
By their numbers in this assay, from the lowest: compounds 2 and 4 (each within the scatter of the next); then compound 3; then compound 1.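

In this assay, a group joined through nitrogen at this aromatic carbon does not always carry a high number: replacing ((thiophen-2-yl)methyl)amino with 4-methylpiperidin-1-yl gives a 5.1-fold lower number from compound 3 to compound 4 (0.71 log units; beyond the scatter), and replacing benzylamino with it gives a 16-fold lower number from compound 1 to compound 4 (1.21 log units; beyond the scatter). The oxygen link of isopropoxy is therefore not required for a low number in this small set: the step between these two groups is a 2.0-fold higher number from compound 2 to compound 4 (0.30 log units; within the scatter), and the two cannot be told apart. Within the data shown here, the high numbers so far belong only to the two arylmethylamino groups, compound 1 and compound 3.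

The change to 4-methylpiperidin-1-yl removes the amino hydrogen and the aromatic ring together, so a benzyl(methyl)amino group or a plain morpholin-4-yl group would be needed to separate those features. Nothing measured here explains why the numbers differ.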